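A few compounds are considered here, and "the series" means these few. Any claim that something is new, unique, unknown or untested is made for them only; others in the source may bear on it.

Measured so far:
Compound 1 `CCCC[C@]1(CC)CS(=O)(=O)c2ccc(N)cc2[C@@H](c2ccccc2)[C@H]1O` gives 68 nM in an assay on cells for inhibition of ileal sodium/bile acid cotransporter (Homo sapiens); a lower number here means a stronger inhibitor, a higher number a weaker inhibitor.
Compound 2 `CCCC1(CCC)CS(=O)(=O)c2ccc(N)cc2[C@@H](c2ccccc2)[C@H]1O` gives 230 nM in this assay.
Compound 3 `CCCCC1(CCCC)CS(=O)(=O)c2cc(OC)ccc2[C@@H](c2ccccc2)[C@H]1O` gives 190 nM in this assay.

Compound 1 has the lowest number of the three; its gaps to compound 3 and to compound 2 both lie beyond the usual scatter. Compound 4 `CCCC[C@]1(CC)CS(=O)(=O)c2ccc([N+](C)(C)C)cc2[C@@H](c2ccccc2)[C@H]1O` is the next candidate, differing from compound 1 in one place: a group of 4 heavy atoms (3 carbon, 1 nitrogen; no ring) in place of one nitrogen atom, on an aromatic carbon. Within the data shown here, no measured pair shows this kind of exchange, so no step of the same type is available for comparison; the expectation rests on compound 1 alone. A modest weakening is expected in this assay, with the step from compound 1 to compound 4 estimated as a 2.2-fold higher number from compound 1 to compound 4 (0.34 log units; beyond the scatter). For compound 4 the expected value is 150 nM, within a range of 40 nM to 600 nM.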

Compound 4, half-maximal inhibitory concentration: 83 nM
The estimate for compound 4 lay 1.8-fold (0.26 log units) above the measured number; low and high end bracket the measured number.
By their numbers in this assay, from the lowest: compounds 1 and 4 (each within the scatter of the next); then compounds 3 and 2 (each within the scatter of the next).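

Exchanging the amino group on this aromatic carbon for the group of 4 heavy atoms with net charge +1 gives a 1.2-fold higher number from compound 1 to compound 4 (0.09 log units; within the scatter) in this assay. Among these compounds, this position therefore takes a larger group with net charge +1 and no hydrogen-bond donors without a step beyond the scatter, which compounds 1, 2 and 3 could not show, as no pair among them differed in one place. No measurement here bears on why this step is so small.

From the compounds shown here alone, how a carboxylic acid or an acetamide on this aromatic carbon would compare with the amino group remains open.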